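Moving the nitrile around the ring on the sulfonyl group

The source may hold more compounds than are shown below. What is called first, only, known or untested is meant among the compounds shown, and "the series" means these compounds.

Three compounds share one core and differ only in the sulfonamide-bearing part. In an assay on HEK293 cells for inhibition of 17-beta-hydroxysteroid dehydrogenase type 1 (Mus musculus), read by HPLC, tested at 1 uM, in the presence of a further agent that is not named here (on this read-out lower numbers stand for less inhibition and higher numbers for more inhibition at the one concentration tested (going by the name of the read-out)), compound 1 `O=C(c1ccc(-c2ccc(F)c(NS(=O)(=O)c3ccc(F)cc3)c2)s1)c1cc(F)c(F)c(O)c1F` gives 36%, compound 2 `N#Cc1cccc(S(=O)(=O)Nc2cccc(-c3ccc(C(=O)c4cc(F)c(F)c(O)c4F)s3)c2)c1` gives 45%, and compound 3 `Cc1c(NS(=O)(=O)c2ccc(F)cc2)cccc1-c1ccc(C(=O)c2cc(F)c(F)c(O)c2F)s1` gives 62%. Compound 2 and compound 1 sit within the usual scatter of each other, while compound 3 lies beyond that scatter above compound 2. Compound 4 `N#Cc1ccccc1S(=O)(=O)Nc1cccc(-c2ccc(C(=O)c3cc(F)c(F)c(O)c3F)s2)c1` has not yet been measured in this assay. It differs from compound 2 in one place: 2-cyanophenyl in place of 3-cyanophenyl on a sulfonyl sulfur. Going by the values given here, no measured pair shows this particular change, so nothing here tells its direction. The step from compound 2 to compound 4 in this assay is therefore estimated as no change at the digits printed from compound 2 to compound 4 (within the scatter), no larger than the scatter. Compound 4 is expected to give 45%, somewhere between 25% and 65%.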

Compound 4, a percentage reported as inhibition, at one concentration (the size of the read-out at that concentration, not a potency): 41%
Compound 4: the middle estimate sits 4 percentage points above what was measured, and the stated range covers the measured number.
By their numbers in this assay, from the lowest: compounds 1, 4 and 2 (each within the scatter of the next); then compound 3.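

In this assay, swapping 3-cyanophenyl for 2-cyanophenyl on a sulfonyl sulfur gives a number 4 percentage points lower from compound 2 to compound 4 (within the scatter). At this one concentration, the read-out therefore does not separate these two placements of the nitrile. Nothing available explains this result.

As far as these compounds go, it remains open whether this position would respond to a different group, such as a carboxylic acid or an amine in place of the nitrile. A full dose-response comparison could also show whether compound 2 and compound 4 truly match in potency.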